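The compounds below may be only part of what the source reports. "The series", "measured", "known", "first", "only" and "open" are said of these compounds alone.

Measured compounds:
compound 1, `Cc1nc2ccccc2n1C1CCN(CCCC(=O)c2ccc(F)cc2)CC1` — in a functional assay on the whole organism (strain STD-ddY) with Mus musculus as the target, with stated times of 1 h and 24 h (a lower number here means that less compound is needed, a higher number that more compound is needed for the effect), compound 1 gives 0.81 mg/kg
compound 2, `O=C(CCCN1CCC(n2c(SCC(=O)c3ccc(Cl)cc3)nc3ccccc32)CC1)c1ccc(F)cc1` — in this assay compound 2 gives 1.6 mg/kg

Among the two numbers recorded in this assay, compound 2 carries the higher one, but its only neighbour is compound 1, and the step between them, a 2.0-fold higher number from compound 1 to compound 2 (0.30 log units; within the scatter), stays inside the scatter, so the two compounds cannot be ordered.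

Compound 3, `CCOC(=O)Sc1nc2ccccc2n1C1CCN(CCCC(=O)c2ccc(F)cc2)CC1`, is the next compound to be measured in this assay. It is reached from compound 2 by a single change: ethoxycarbonyl in place of ((4-chlorophenyl)carbonyl)methyl on a sulfur

Within the data shown here, the one measured step that bears on this position is a 2.0-fold higher number from compound 1 to compound 2 (0.30 log units; within the scatter), in which the whole (((4-chlorophenyl)carbonyl)methyl)sulfanyl group was introduced in place of methyl on an aromatic carbon without a shift beyond the scatter. Compound 3 keeps the sulfur on the core of compound 2 and exchanges only the group attached to it. On that basis the expectation for compound 3 is a step of a 1.3-fold lower number from compound 2 to compound 3 (0.12 log units; within the scatter), that is, no change beyond the scatter. Compound 3 is therefore estimated at 1.2 mg/kg, with a range from 0.5 mg/kg to 3 mg/kg.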

Compound 3, dose for half-maximal effect: 0.65 mg/kg
The estimate for compound 3 lay 1.8-fold (0.27 log units) above the measured number, and the stated range covers the measured number.
By their numbers in this assay, from the lowest: compounds 3, 1 and 2 (each within the scatter of the next, the first and the last beyond it).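

In this assay, the group on the sulfur is shown to make a measurable difference: replacing ((4-chlorophenyl)carbonyl)methyl with ethoxycarbonyl gives a 2.5-fold lower number from compound 2 to compound 3 (0.39 log units; beyond the scatter), the first single change here to pass beyond the scatter, though only modestly. The same position also tolerates this sulfur-linked group when measured against the small original substituent, since (ethoxycarbonyl)sulfanyl in place of methyl on an aromatic carbon gives a 1.2-fold lower number from compound 1 to compound 3 (0.10 log units; within the scatter), so the two cannot be ordered. No measurement offered here accounts for the difference between the two groups on the sulfur.

The change removes the 4-chlorophenyl ring and replaces the ketone-bearing chain with ethoxycarbonyl in one move, so the compounds shown do not separate the contribution of the ring from that of the linking atoms. Nor do they show how this position responds to a plain ethyl or benzyl group on the sulfur, to an amide in place of the ethoxycarbonyl, or to a carboxylic acid or an amine at the end of a longer chain.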